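Trading Trifluoromethoxy for Trifluoromethyl: A Small Step Expected

The compounds below may be only part of what the source reports. "The series", "measured", "known", "first", "only" and "open" are said of these compounds alone.

In a functional assay on Jurkat cells (Homo sapiens) for cytotoxicity, read by luminescence and CellTiter-Glo, with a stated time of 3 days (on this read-out lower numbers stand for stronger inhibition and higher numbers for weaker inhibition), compound 2 (`O=C(Nc1ccc(OC(F)(F)F)cc1)c1cc(F)ccc1O`) gives 810 nM and sits within the usual scatter of compound 1 (`O=C(Nc1ccc(C(F)(F)F)cc1)c1cc(Cl)ccc1O`), which gives 710 nM on the same read-out. With only these two numbers in hand, neither compound can be ranked above the other.

Compound 3 (`O=C(Nc1ccc(C(F)(F)F)cc1)c1cc(F)ccc1O`) differs from compound 2 in one place: trifluoromethyl in place of trifluoromethoxy on an aromatic carbon. Among the compounds with values here, no measured pair yet shows what this swap does in this assay and any forecast must stay cautious. Compound 1 also carries trifluoromethyl, and at 710 nM it lies within the scatter of compound 2, which points to little change. The expected 1.1-fold lower number from compound 2 to compound 3 (0.03 log units; within the scatter) stays within the scatter, with no clear direction. For compound 3 the estimated value is 750 nM with an expected range from 350 nM to 1600 nM.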

Compound 3, half-maximal inhibitory concentration: 580 nM
For compound 3 the middle estimate is 1.3-fold (0.11 log units) above the measured one; low and high end bracket the measured number.
By their numbers in this assay, from the lowest: compounds 3, 1 and 2 (each within the scatter of the next).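

The swap of trifluoromethoxy for trifluoromethyl now has a measured pair: in this assay it gives a 1.4-fold lower number from compound 2 to compound 3 (0.15 log units; within the scatter), so the two groups cannot be told apart at this place on the ring on this read-out. The second single change, fluoro in place of chloro on an aromatic carbon, gives a 1.2-fold lower number from compound 1 to compound 3 (0.09 log units; within the scatter), so these two atoms cannot be told apart here either. Nothing measured here bears on what lies behind these two results.

As far as these compounds go, what stays open is whether a group of a different kind at the place of the trifluoromethyl, such as an amine or a carboxylic acid, would move the number beyond the scatter. The same question holds where fluoro and chloro sit, for example for a nitrile or a methoxy group.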